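The source may hold more compounds than are shown below. What is called first, only, known or untested is meant among the compounds shown, and "the series" means these compounds.

Compound 1 `COC(=O)c1c(-c2ccc(O)cc2)oc2ccc(OC)cc2c1=O`: 18.7 ug/mL
Compound 2 `COc1cc(OC)cc(-c2oc3ccccc3c(=O)c2C(=O)O)c1`: > 25 ug/mL
Compound 3 `COc1cc(-c2cc(=O)c3cc(O)ccc3o2)cc(OC)c1OC`: 5.87 ug/mL

In a functional assay on SK-MEL cells (Homo sapiens) for cytotoxicity, read by MTT assay, with a stated time of 6 days (a higher number here means that more compound is needed for the effect, a lower number that less compound is needed), compound 3 gives 5.87 ug/mL, the lowest of the two exact numbers. Compound 1, the nearest, gives 18.7 ug/mL, higher by more than the scatter. Compound 2 gives only a limit, > 25 ug/mL.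

Compound 4 `COc1cc(-c2cc(=O)c3cc(O)ccc3o2)cc(OC)c1O` differs from compound 3 by hydrogen in place of methyl on an oxygen on an aromatic ring, a change of methoxy to hydroxy. Among the compounds with values here, no measured pair shows this change, so in this assay only a small rise, within the scatter, is expected. The expected change is a 1.4-fold higher number from compound 3 to compound 4 (0.13 log units; within the scatter). For compound 4 the estimated value is 8 ug/mL, with an expected range of 3 ug/mL to 20 ug/mL.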

Compound 4, concentration for half-maximal effect: 5.68 ug/mL
Estimate against measurement, compound 4: 1.4-fold (0.15 log units) above; measured number inside the range.
By their numbers in this assay, from the lowest: compounds 4 and 3 (each within the scatter of the next); then compound 1. At a limit, above all of these: compound 2.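

In this assay, within the data shown here, this is the only measured pair that differs in one place, and it gives a 1.0-fold lower number from compound 3 to compound 4 (0.01 log units; within the scatter). On this oxygen on an aromatic ring, then, hydrogen can take the place of methyl with no difference that this measurement can separate from the scatter. Nothing shown here offers a reason for this outcome.

As far as these compounds go, whether a longer chain or a chain ending in an amine on this same oxygen would give a similar number remains open. From the compounds shown here alone, it is also open whether methoxy to hydroxy at the other methoxy groups of compound 3 would read the same way.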